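Removal of the oxolan-3-yl ring from the exocyclic amine

A few compounds are considered here, and "the series" means these few. Any claim that something is new, unique, unknown or untested is made for them only; others in the source may bear on it.

Measured so far:
compound 1 `CCCn1c(-c2ccccc2)nc2c(NC3CCOC3)ncnc21` — 25 nM
compound 2 `Cn1c(-c2ccccc2)nc2c(NC3CCOC3)ncnc21` — 8 nM

Among the measured compounds shown here, in an assay on CHO cells for displacement of a labelled ligand from adenosine receptor A1 (Homo sapiens), read by scintillation counting, with a stated time of 3 h (on this read-out higher numbers stand for weaker inhibition and lower numbers for stronger inhibition), compound 1 gives 25 nM, the higher of the two numbers; the one measured step, a 3.1-fold lower number from compound 1 to compound 2 (0.49 log units; beyond the scatter), concerns the chain on the aromatic nitrogen, not the exocyclic amine. Compound 3 `CCCn1c(-c2ccccc2)nc2c(N)ncnc21` differs from compound 1 by hydrogen in place of oxolan-3-yl on a nitrogen on an aromatic ring. For the measured compounds named here, no measured step touches this position, so the expectation rests on the structural change alone: loss of the ring is expected to raise the number, a step of a 4.0-fold higher number from compound 1 to compound 3 (0.60 log units; beyond the scatter), with wide uncertainty. For compound 3 a value of 100 nM is estimated, within 20 nM to 600 nM.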

Compound 3, inhibition constant: 101 nM
The estimate for compound 3 lay 1.0-fold (0.00 log units) below the measured number; measured number inside the range.
By their numbers in this assay, from the lowest: compound 2; then compound 1; then compound 3.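

Among the compounds shown here, replacing oxolan-3-yl with hydrogen on this nitrogen gives the first measured step at this position in this assay (a 4.0-fold higher number from compound 1 to compound 3 (0.61 log units; beyond the scatter)). The number therefore responds to this substituent, with the ring-bearing compound 1 giving the lower number, yet compound 3 still gives a finite value without the ring (101 nM). No available evidence bears on the reason for this step.

Open, going by these compounds, is whether a cyclopentyl ring, a tetrahydropyranyl ring or a simple butyl chain on this nitrogen would match oxolan-3-yl. Also open, on these data alone, is whether the step carries over to the shorter chain of compound 2.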